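The source may hold more compounds than are shown below. What is called first, only, known or untested is meant among the compounds shown, and "the series" means these compounds.

Series notes. Two dichloroacetamide anilides are recorded: compound 1 `Cc1ccccc1NC(=O)C(Cl)Cl` and compound 2 `O=C(Nc1ccc(Cl)cc1)C(Cl)Cl`. In a functional assay on Bel-7402 cells (Homo sapiens) for antiproliferative activity, read by MTT assay, with a stated time of 72 h (on this read-out lower numbers stand for stronger inhibition and higher numbers for weaker inhibition), compound 1 gives "not determined" (no result reported). In this assay, within the data shown here, compound 2 gives 49600 nM, the only number in hand, so compound 2 is the sole reference point and no step between measured compounds exists.

Compound 3 `O=C(Nc1ccc(SC(F)(F)F)cc1)C(Cl)Cl` follows from compound 2 by (trifluoromethyl)sulfanyl in place of chloro on an aromatic carbon. Among the measured compounds shown here, with no measured precedent for this exchange, the step is expected to be small, a 1.6-fold lower number from compound 2 to compound 3 (0.19 log units; within the scatter), and not clearly beyond the scatter. Compound 3 is accordingly estimated at 32000 nM, with a range of 10000 nM to 100000 nM.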

Compound 3, half-maximal inhibitory concentration: 3610 nM
Compound 3: middle estimate off by 8.9-fold (0.95 log units), on the high side; measured number outside the range, below it.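

On the aromatic carbon para to the group of 6 heavy atoms, the series now shows a response to substitution: in this assay, (trifluoromethyl)sulfanyl in place of chloro gives a 14-fold lower number from compound 2 to compound 3 (1.14 log units; beyond the scatter). Among these compounds, this is the first readable step, and it shows that the number at this position depends on the group placed there. No measured information on the origin of this step is available.

A methylsulfanyl or a trifluoromethyl group on this carbon would separate the contributions of the sulfur and the fluorines. As far as these compounds go, how an amine or a carboxylic acid would read here remains open.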